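A few compounds are considered here, and "the series" means these few. Any claim that something is new, unique, unknown or untested is made for them only; others in the source may bear on it.

In a functional assay (aorta) with Rattus norvegicus as the target (on this read-out higher numbers stand for an effect only at larger amounts of compound and lower numbers for an effect already at smaller amounts), compound 1 (`CCNC1=NS(=O)(=O)c2cc(F)ccc2N1`) gives only a limit of the assay (> 300 uM). Compound 2 (`C=CCNC1=Nc2ccc(F)cc2S(=O)(=O)N1`) also gives only a limit (> 300 uM). Compound 3 (`CCNC1=NS(=O)(=O)c2cc(Cl)ccc2N1`) gives a true number (39.9 uM) and is the only one of the three with a measured value.

The change to compound 4 (`CCC(CC)NC1=NS(=O)(=O)c2cc(Cl)ccc2N1`) is pentan-3-yl in place of ethyl on an amine nitrogen and puts pentan-3-yl in place of ethyl on an amine nitrogen, with the rest of the core of compound 3 kept. Among the measured compounds shown here, only one measured step is at hand, and it bears on this change only indirectly. That step is an at least 7.5-fold lower number from compound 1 to compound 3 (0.87 log units; beyond the scatter) and it concerns an aromatic carbon, not the amine nitrogen. For the measured compounds named here, it shows that a single exchange on this core can move the number beyond the scatter, but no step at the amine nitrogen has been measured. A modest step is therefore expected, and the direction is tentative, with a slight lean toward a lower number. The estimated move is a 2.7-fold lower number from compound 3 to compound 4 (0.42 log units; beyond the scatter) and it remains uncertain. For compound 4 the expected value is 15 uM with an estimated range from 3 uM to 80 uM in this assay.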

Compound 4, concentration for half-maximal effect: 93.6 uM
Estimate against measurement, compound 4: 6.2-fold (0.80 log units) below; the measured number lies above the stated range.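

The amine nitrogen now has a measured step of its own: in this assay, there is a 2.3-fold higher number from compound 3 to compound 4 (0.37 log units; beyond the scatter). The exchange of ethyl for pentan-3-yl thus moves the number upward, against the downward move seen at the aromatic carbon, where there is an at least 7.5-fold lower number from compound 1 to compound 3 (0.87 log units; beyond the scatter). Even so, with the chloro group kept and the larger pentan-3-yl on the amine nitrogen, compound 4 still gives a true number of 93.6 uM.

A single step at this nitrogen cannot tell whether the higher number goes with the count of carbon atoms or with the branching of pentan-3-yl, and an unbranched propyl or butyl chain, a cyclopentyl ring or a chain ending in a hydroxyl group would bear on that question. The fluoro compounds add nothing on this nitrogen, as any step between compound 1 and compound 2 cannot be read, both giving only a limit of the assay: the limit of > 300 uM in this assay, at which 2 of the 4 values shown sit.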